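Replacing the hydroxy of compound 1 with chloro

The source may report more compounds than this note shows. Statements on the series, on what has been measured and on what is new or still open speak of the compounds shown alone.

Going by the values given here, in a functional assay on HepG2 cells (Homo sapiens) for cytotoxicity, read by CCK-8 assay (on this read-out higher numbers stand for weaker inhibition and lower numbers for stronger inhibition), compound 1 `O=C(Nc1ccc(O)cc1)c1ncc(-c2ccccc2)o1` gives 1270 nM and is the only compound with a true number so far. Compound 2 `O=C(Nc1cccc(O)c1)c1ncc(-c2ccccc2)o1` gives > 30000 nM as a limit of the assay. Compound 3 `Cc1ccc(NC(=O)c2ncc(-c3ccccc3)o2)cc1` gives > 30000 nM as a limit too. Compound 4 `O=C(Nc1ccc(Cl)cc1)c1ncc(-c2ccccc2)o1` is still unmeasured and carries chloro in place of hydroxy on an aromatic carbon, para to a large group (chloro in place of hydroxy on an aromatic carbon). Moving the hydroxy produced an at least 23-fold higher number from compound 1 to compound 2 (1.37 log units; beyond the scatter) as a large step beyond the scatter. Replacing it with methyl is the closer guide: an at least 23-fold higher number from compound 1 to compound 3 (1.37 log units; beyond the scatter) was also large, so a large step toward weaker inhibition is expected in this assay here. The estimated step is a 9.4-fold higher number from compound 1 to compound 4 (0.98 log units; beyond the scatter) and the assay may report only a limit. Compound 4 is estimated at 12000 nM within a range from 2500 nM to 30000 nM for now.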

Compound 4, half-maximal inhibitory concentration: > 30000 nM
Compound 4 was reported as a limit (the forecaster's own chance of this, stated with the estimate: 50%); middle value at least 2.5-fold (0.39 log units) away from the limit.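

Going from 4-hydroxyphenyl to 4-chlorophenyl in this assay gives an at least 23-fold higher number from compound 1 to compound 4 (1.37 log units; beyond the scatter), and the value of compound 4 is a limit of the assay, not a number. Together with compound 3, this makes two replacements of the hydroxy at this place, and neither gives a true number, so among the compounds shown only compound 1 does. The steps among compound 2, compound 3 and compound 4 cannot be read, because all three rest on the same limit: the limit of > 30000 nM in this assay, at which 3 of the 4 values shown sit.

How far beyond that limit each of these compounds lies stays unknown. From the compounds shown here alone, it is also open whether an amine or a carboxylic acid at this place would restore a true number.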